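Solubility notes: acetylpiperidine to methylpiperazine on the carbonyl

The compounds below may be only part of what the source reports. "The series", "measured", "known", "first", "only" and "open" are said of these compounds alone.

Within the data shown here, compound 3 `CC(=O)N1CCC(C(=O)N2Cc3c(NC(=O)c4ccc(F)cc4)n[nH]c3C2(C)C)CC1` is the one member of the set with a measured number in a physicochemical assay for solubility, at pH 7; a lower number here means a less soluble compound, a higher number a more soluble compound: compound 3 gives 204000 nM. Compound 1 `CC1(C)c2[nH]nc(NC(=O)c3ccc(F)cc3)c2CN1C(=O)C1CCN(C2CC2)CC1` reaches a limit of the assay, > 225000 nM. Compound 2 `CN1CCC(C(=O)N2Cc3c(NC(=O)Nc4cccc(F)c4)n[nH]c3C2(C)C)CC1` likewise reaches a limit, > 225000 nM. Compound 3 thus holds the only number shown, with the two other values being limits; the limit of > 225000 nM in this assay, at which 2 of the 3 values shown sit, marks where those sit. Among the measured compounds shown here, the single measured step, an at least 1.1-fold lower number from compound 1 to compound 3 (0.04 log units; that floor lies within the scatter), covers acetyl in place of cyclopropyl on an amine nitrogen in a ring and stays within the scatter.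

Compound 4 `CN1CCN(C(=O)N2Cc3c(NC(=O)c4ccc(F)cc4)n[nH]c3C2(C)C)CC1` is to be measured in this assay. Its change from compound 3 is 4-methylpiperazin-1-yl in place of 1-acetylpiperidin-4-yl on a carbonyl carbon. No measured step covers an exchange on the carbonyl carbon; the only step shown concerns an amine nitrogen in a ring and is within the scatter. A step of a 1.1-fold higher number from compound 3 to compound 4 (0.04 log units; within the scatter) is therefore expected, not beyond the scatter, with a fair chance that only a limit is reported. Compound 4 is estimated at 225000 nM, between 110000 nM and 450000 nM.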

Compound 4, solubility: > 225000 nM
Compound 4: a limit, no number; the forecaster's own chance of this, stated with the estimate: 55%; the middle value lies on the limit itself.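

In this assay, 4-methylpiperazin-1-yl in place of 1-acetylpiperidin-4-yl gives the first step read on a carbonyl carbon, with no measured size: an at least 1.1-fold higher number from compound 3 to compound 4 (0.04 log units; that floor lies within the scatter). The value of compound 4 is a limit, so this step gives only a floor, and the step from compound 1 to compound 4 joins two limits and cannot be read. Most of the set now reads as a limit and not as a number: the limit of > 225000 nM in this assay, at which 3 of the 4 values shown sit.

Still open, going by these compounds, is how far compound 4 actually lies from compound 3, and so whether this exchange on the carbonyl carbon changes the read-out at all. Also open, on these data alone, is whether a carboxylic acid or a longer alkyl chain on this carbonyl carbon would give a measured number in this assay.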